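Trimming a Methyl from the Oxime Ether Side Chain

The source may report more compounds than this note shows. Statements on the series, on what has been measured and on what is new or still open speak of the compounds shown alone.

Compound 3, `CO/N=C(\C)c1ccccc1NCC1=NCCN1`, joins the shared core to a methoxyimino-bearing side chain. In a functional assay for activation of Alpha-1D adrenergic receptor (Homo sapiens) (on this read-out lower numbers stand for an effect already at smaller amounts and higher numbers for an effect only at larger amounts of compound), compound 3 gives only a limit of < 5020 nM. Compound 1, `Cc1ccsc1-c1ccccc1NCC1=NCCN1`, carries a 3-methylthiophen-2-yl group at the same place of the core and gives 49 nM in this assay. Compound 2, `Cc1noc(-c2ccccc2NCC2=NCCN2)n1`, carries a 3-methyl-1,2,4-oxadiazol-5-yl group there and in this assay gives only a limit of < 5020 nM. The steps a step that the limit leaves unreadable from compound 1 to compound 3 and a step that the two limits leave unreadable from compound 2 to compound 3 cannot be sized because two of the three values sit at the limit of < 5020 nM in this assay, at which 2 of the 3 values shown sit.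

Compound 4, `CO/N=C/c1ccccc1NCC1=NCCN1`, differs from compound 3 by a group of 4 heavy atoms (2 carbon, 1 nitrogen, 1 oxygen; no ring) in place of a group of 5 heavy atoms (3 carbon, 1 nitrogen, 1 oxygen; no ring), on an aromatic carbon. Among the compounds with values here, none of the measured steps removes a single methyl in this way; the steps that touch this place exchange whole side groups and are unreadable in size. The expectation for compound 4 therefore rests on the limit of compound 3 alone, and a step that the limit leaves unreadable from compound 3 to compound 4 in this assay is expected, no larger than the scatter. Compound 4 is estimated at 1500 nM in this assay, within a range from 200 nM to 5020 nM, with a fair chance that only a limit is again reported.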

Compound 4, half-maximal effective concentration: < 5020 nM
Compound 4: only a limit was reported; the forecaster's own chance of this, stated with the estimate: 45%; the middle value lies beyond the limit too.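

No new step can be read from compound 4 to compound 1, compound 2 or compound 3, because the values sit at a limit: the limit of < 5020 nM in this assay, at which 3 of the 4 values shown sit. The compounds shown leave open whether the smaller group of compound 4 changes the read-out of this assay relative to compound 3, and how far compound 2, compound 3 and compound 4 lie from compound 1.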